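The source may report more compounds than this note shows. Statements on the series, on what has been measured and on what is new or still open speak of the compounds shown alone.

Measured in a functional assay on MDA-MB-231 cells (Homo sapiens) for antiproliferative activity, read by MTT assay, with a stated time of 48 h; on this read-out higher numbers stand for weaker inhibition and lower numbers for stronger inhibition:
- compound 1 `COC(=O)/C(=C/c1ccccc1)CN1C(=O)[C@@H](OC)[C@H]1c1ccc(F)cc1` gives 21800 nM
- compound 2 `COc1ccc(OC)c([C@@H]2[C@H](OC)C(=O)N2C/C(C#N)=C/c2ccccc2)c1` gives 23400 nM

These two numbers lie within the usual scatter of repeated measurements, so compound 1 and compound 2 cannot be ranked against each other in this assay. Among the compounds with values here, compound 1 therefore stands level with the only other measured compound.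

The next compound to be tested, compound 3 `COC(=O)/C(=C/c1ccccc1)CN1C(=O)[C@@H](OC)[C@H]1c1cccc(F)c1`, is a close relative of compound 1. The change is 3-fluorophenyl in place of 4-fluorophenyl on a saturated ring carbon. The two compounds have the same atoms, joined differently.

Within the data shown here, no pair of measured compounds differs in just one place, so the data offer no direct guide to the size of this step. With nothing to suggest a shift in either direction, the expectation rests on compound 1 at 21800 nM and predicts no change beyond the scatter. The estimated step is a 1.1-fold lower number from compound 1 to compound 3 (0.04 log units; within the scatter), with no direction claimed. The estimated value for compound 3 is 20000 nM, with an expected range of 9000 nM to 42000 nM.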

Compound 3, half-maximal inhibitory concentration: 34400 nM
Estimate against measurement, compound 3: 1.7-fold (0.24 log units) below; low and high end bracket the measured number.
By their numbers in this assay, from the lowest: compounds 1, 2 and 3 (each within the scatter of the next).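

In this assay, within the data shown here, placing 3-fluorophenyl instead of 4-fluorophenyl on the saturated ring carbon gives a 1.6-fold higher number from compound 1 to compound 3 (0.20 log units; within the scatter) as the first single-place step in this small set. The step stays inside the normal spread of repeated measurements, even though the atoms of the group are joined differently, so the two fluorophenyl groups cannot be told apart at this position in this assay. No independent measurement is available to explain this outcome.

Among these compounds, this single exchange tests only two fluorophenyl groups on the core of compound 1, so it does not show how much freedom this position allows for other groups. A plain phenyl, an aminophenyl, a hydroxyphenyl or a pyridine ring at the same carbon could show whether changes here can shift antiproliferative activity beyond that spread, or whether this position has little influence on the read-out.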